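The compounds below may be only part of what the source reports. "The series", "measured", "known", "first", "only" and "open" are said of these compounds alone.

Measured compounds and their values in an assay on THP-1 cells for displacement of a labelled ligand from C-C chemokine receptor type 1 (Homo sapiens); on this read-out lower numbers stand for stronger inhibition and higher numbers for weaker inhibition:

Compound 1 `CC(C)C(NS(=O)(=O)Cc1ccccc1)C(=O)N1CCC(c2ccc(Cl)cc2)CC1` gives 303 nM
Compound 2 `CC[C@@H](NC(=O)c1ccccc1)C(=O)N1CCC(c2ccc(Cl)cc2)CC1` gives 121 nM
Compound 3 `CC(C)[C@@H](NC(=O)c1cccc(F)c1)C(=O)N1CCC(c2ccc(Cl)cc2)CC1` gives 24 nM

All three compounds share the same core carrying a chlorophenyl-substituted piperidine amide; they differ in the side chain and in the group attached to the nitrogen. Compound 3 stands at the lowest number of the three in this assay. The nearest value, that of compound 2, lies beyond the usual scatter of the measurement, and the value of compound 1 lies further still. Compound 3 is therefore the most potent of the measured set.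

Compound 4 `Cc1ccccc1CCC(=O)N[C@@H](C(=O)N1CCC(c2ccc(Cl)cc2)CC1)C(C)C` has not yet been measured. It is derived from compound 3 by a single change on the carbonyl carbon attached to the amide-type nitrogen: 2-(2-methylphenyl)ethyl in place of 3-fluorophenyl on a carbonyl carbon. Going by the values given here, no measured pair isolates a change of this kind, so the step from compound 3 to compound 4 cannot be read from the existing numbers. Among the compounds with values here, the flat aromatic group directly on the carbonyl is exchanged for a longer, chain-linked one, and the only other compound with a chain between the aromatic ring and the attachment point, compound 1, sits at the highest number of the set.

On that basis the step is expected to raise the number beyond the scatter: a 4.6-fold higher number from compound 3 to compound 4 (0.66 log units; beyond the scatter). Compound 4 is estimated at 110 nM, with a range from 30 nM to 400 nM.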

Compound 4, half-maximal inhibitory concentration: 19 nM
Compound 4: the middle estimate sits 5.8-fold (0.76 log units) above what was measured; the measured number lies below the stated range.
By their numbers in this assay, from the lowest: compounds 4 and 3 (each within the scatter of the next); then compound 2; then compound 1.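

In this assay, the place on the carbonyl carbon whose other neighbour is the amide-type nitrogen takes 2-(2-methylphenyl)ethyl in place of 3-fluorophenyl with a 1.3-fold lower number from compound 3 to compound 4 (0.10 log units; within the scatter), so the two compounds cannot be told apart on this read-out. Going by these compounds alone, this is the first step that isolates a single place, and it shows that here the aromatic ring need not stand directly on the carbonyl carbon: a group of 9 heavy atoms with a two-carbon link serves as well as the group of 7 heavy atoms it replaces. Nothing at hand explains why the two groups read alike.

As far as these compounds go, the step exchanges the link and the ring substituent together, so the share of each stays open; an unsubstituted 2-phenylethyl group, or a 2-(3-fluorophenyl)ethyl group, in this place would separate them. From the compounds shown here alone, how far the place stays open to other groups is also unsettled, and a longer chain, an amine or a carboxylic acid here would mark its limits.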